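This account rests on a few compounds, and the source may have more. Where it says the series, first, only, none or still open, it means among the compounds named here.

Three amides of a shared core have been measured in a functional assay on Caco-2 cells (Homo sapiens), read by MTT assay, with a stated time of 48 h (a lower number here means a stronger inhibitor, a higher number a weaker inhibitor), where compound 1 (`CCN(CC)CCNC(=O)c1ccc(C(CC)(CC)c2ccc(OCC(O)C(C)(C)C)c(C)c2)n1CC`) gives 2310 nM. Compound 2 (`C#CCNC(=O)c1ccc(C(CC)(CC)c2ccc(OCC(O)C(C)(C)C)c(C)c2)n1CC`) gives 39100 nM in this assay. Compound 3 (`CCn1c(C(=O)NCC(OC)OC)ccc1C(CC)(CC)c1ccc(OCC(O)C(C)(C)C)c(C)c1`) gives only a limit, > 50000 nM in this assay.

Compound 4 (`C=CCN(C)C(=O)c1ccc(C(CC)(CC)c2ccc(OCC(O)C(C)(C)C)c(C)c2)n1CC`) has allyl(methyl)amino in place of the (2,2-dimethoxyethyl)amino of compound 3 on a carbonyl carbon (allyl(methyl)amino in place of (2,2-dimethoxyethyl)amino on a carbonyl carbon). Within the data shown here, no measured step makes this exact change, so the evidence is indirect. Two large steps, a 17-fold higher number from compound 1 to compound 2 (1.23 log units; beyond the scatter) and an at least 21-fold higher number from compound 1 to compound 3 (1.33 log units; beyond the scatter), both remove the (diethylamino)methyl, which compound 4 also lacks. The third measured step is an at least 1.2-fold higher number from compound 2 to compound 3 (0.10 log units; that floor lies within the scatter) and rests on a limit.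

Compound 4 is therefore expected to stay in the weak range of compound 2, which gives 39100 nM, without regaining the value of compound 1. The expected change is modest, estimated as an at least 1.4-fold lower number from compound 3 to compound 4 (0.15 log units; that floor lies within the scatter) in this assay. For compound 4 the expected value is 35000 nM (estimated range 15000 nM to 70000 nM).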

Compound 4, half-maximal inhibitory concentration: > 50000 nM
Compound 4: no number, only a limit (the forecaster's own chance of this, stated with the estimate: 40%); middle value at least 1.4-fold (0.15 log units) from the limit.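

In this assay compound 4 gives > 50000 nM as a limit of the assay and not as a number, so allyl(methyl)amino on this carbonyl carbon, with 0 hydrogen-bond donors, still leaves the amide weak. Among these compounds, the readable steps are an at least 21-fold higher number from compound 1 to compound 4 (1.33 log units; beyond the scatter) and an at least 1.2-fold higher number from compound 2 to compound 4 (0.10 log units; that floor lies within the scatter) so a third group lacking the (2-(diethylamino)ethyl)amino stays well apart from the one amide that carries it, with no compound here going against this, while the second floor gives no order. The step from compound 3 to compound 4 cannot be read because both compounds sit at the limit: the limit of > 50000 nM in this assay, at which 2 of the 4 values shown sit.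

On these data alone, whether the diethylamino group itself or the length of its chain sets the value of compound 1 stays open, for instance with a dimethylamino group or a longer chain on the same amide. As far as these compounds go, how far compound 2, compound 3 and compound 4 truly lie apart also stays open, with two of them given only as limits.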